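From 3-chlorophenyl to 3-hydroxyphenyl in a growth assay

This account rests on a few compounds, and the source may have more. Where it says the series, first, only, none or still open, it means among the compounds named here.

In a functional assay on MCF7 cells (Homo sapiens) for inhibition, read by fluorescence, with a stated time of 72 h (on this read-out lower numbers stand for stronger inhibition of growth and higher numbers for weaker inhibition of growth), compound 1 `CC(C)CCn1cnc2c(Nc3ccc(Cl)cc3)nc(N[C@H]3CC[C@H](N)CC3)nc21` gives 2700 nM and compound 2 `CC(C)CCn1cnc2c(Nc3cccc(Cl)c3)nc(N[C@H]3CC[C@H](N)CC3)nc21` gives 2100 nM. Going by the values given here, these two values lie within the scatter of each other, so compound 2 stands level with compound 1 on the numbers so far. Compound 3 `CC(C)CCn1cnc2c(Nc3cccc(O)c3)nc(N[C@H]3CC[C@H](N)CC3)nc21` has hydroxy in place of chloro on an aromatic carbon, meta to a large group: hydroxy in place of chloro on an aromatic carbon. Among the compounds with values here, only one measured step bears on this change, a 1.3-fold lower number from compound 1 to compound 2 (0.11 log units; within the scatter), and it is small. Within the data shown here, that step exchanges 4-chlorophenyl for 3-chlorophenyl and keeps the chloro, so it offers only indirect guidance, and no measured pair replaces chloro with another group. No change beyond the scatter is therefore expected, though with wide uncertainty. The expected step is a 1.2-fold higher number from compound 2 to compound 3 (0.08 log units; within the scatter). The estimate for compound 3 is 2500 nM, with an expected range from 900 nM to 7000 nM.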

Compound 3, concentration for 50% growth inhibition: 12600 nM
Estimate against measurement, compound 3: 5.0-fold (0.70 log units) below; measured number outside the range, above it.
By their numbers in this assay, from the lowest: compounds 2 and 1 (each within the scatter of the next); then compound 3.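

In this assay, going by these compounds alone, hydroxy in place of chloro on an aromatic carbon, meta to a large group, is the first change here to move the number beyond the scatter, a 6.0-fold higher number from compound 2 to compound 3 (0.78 log units; beyond the scatter). The earlier step, a 1.3-fold lower number from compound 1 to compound 2 (0.11 log units; within the scatter), stayed within the scatter and kept the chloro, whereas a 4.7-fold higher number from compound 1 to compound 3 (0.67 log units; beyond the scatter) also lies beyond it, so compound 3 shows weaker inhibition of growth than both chlorophenyl compounds. Nothing available explains why this exchange weakens inhibition of growth.

The compounds shown leave open whether this weakening is particular to hydroxy or would follow other replacements of chloro at this place, such as methoxy, an amine or fluoro. They also leave open whether a 4-hydroxyphenyl group would compare with 4-chlorophenyl in the same way.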